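This account rests on a few compounds, and the source may have more. Where it says the series, first, only, none or still open, it means among the compounds named here.

Compound 1 `CCCCC#Cc1cc([C@@H]2O[C@H](CO)[C@@H](O)[C@H]2O)n2ncnc(N)c12` sits second highest of the three numbers measured in a functional assay on K562 cells (Homo sapiens) for antiproliferative activity, with a stated time of 72 h (on this read-out higher numbers stand for weaker inhibition and lower numbers for stronger inhibition), where compound 1 gives 2400 nM. Compound 2 `Nc1ncnn2c([C@@H]3O[C@H](CO)[C@@H](O)[C@H]3O)cc(C#CC3CC3)c12` gives 40 nM, and compound 3 `Nc1ncnn2c([C@@H]3O[C@H](CO)[C@@H](O)[C@H]3O)cc(-c3ccc(Cl)cc3)c12` gives 47800 nM. The steps are all large: a 60-fold lower number from compound 1 to compound 2 (1.78 log units; beyond the scatter), a 20-fold higher number from compound 1 to compound 3 (1.30 log units; beyond the scatter) and a 1200-fold higher number from compound 2 to compound 3 (3.08 log units; beyond the scatter).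

Compound 4 `Nc1ncnn2c([C@@H]3O[C@H](CO)[C@@H](O)[C@H]3O)cc(/C=C/c3ccccc3)c12` differs from compound 1 by 2-phenylethenyl in place of hex-1-yn-1-yl on an aromatic carbon. For the measured compounds named here, the step that bears most on it is the one to compound 3, a 20-fold higher number from compound 1 to compound 3 (1.30 log units; beyond the scatter), where the hex-1-yn-1-yl group was likewise exchanged for an aryl group; that step was large and toward weaker inhibition. Compound 4 keeps a two-carbon link to its ring, unlike compound 3, so the loss is expected to be smaller but in the same direction. For compound 4 a step of a 3.3-fold higher number from compound 1 to compound 4 (0.52 log units; beyond the scatter) in this assay is expected. Compound 4 is therefore estimated at 8000 nM, with a range from 1500 nM to 40000 nM.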

Compound 4, half-maximal inhibitory concentration: 3100 nM
Estimate against measurement, compound 4: 2.6-fold (0.41 log units) above; measured number inside the range.
By their numbers in this assay, from the lowest: compound 2; then compounds 1 and 4 (each within the scatter of the next); then compound 3.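

At this aromatic carbon, the step of a 1.3-fold higher number from compound 1 to compound 4 (0.11 log units; within the scatter) shows that 2-phenylethenyl can stand in place of hex-1-yn-1-yl with no readable change in this assay and so a triple bond is not needed there for a number of this size. The step of a 15-fold lower number from compound 3 to compound 4 (1.19 log units; beyond the scatter) shows that an aromatic ring of carbon in this group does not by itself bring the weak number of compound 3, although the chlorine and the double-bonded link change together in that step. The step of a 78-fold higher number from compound 2 to compound 4 (1.89 log units; beyond the scatter) leaves compound 2 alone at the low end of the series.

From the compounds shown here alone, whether compound 2 owes its number to the cyclopropyl ring or to the triple bond stays open, and a 2-cyclopropylethenyl group or an alkyne ending in an amine would bear on that. Nothing available here explains any of these steps.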